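This account rests on a few compounds, and the source may have more. Where it says the series, first, only, none or still open, it means among the compounds named here.

Compound 3 `O=C1/C(=C\c2ccccc2Cl)c2ccccc2N1c1c(Cl)cccc1Cl` carries a 2-chlorophenyl group on the chain carbon of the shared core. In a functional assay on HuTu80 cells (Homo sapiens) for cytotoxicity, read by MTT assay, with a stated time of 72 h (on this read-out higher numbers stand for an effect only at larger amounts of compound and lower numbers for an effect already at smaller amounts), compound 3 gives > 100 ug/mL, which is a limit of the assay and not a number. Compound 1 `CN(C)c1ccc(/C=C2\C(=O)N(c3c(Cl)cccc3Cl)c3ccccc32)cc1` in this assay gives < 1 ug/mL, also a limit. Compound 2 `COc1ccc(/C=C2\C(=O)N(c3c(Cl)cccc3Cl)c3ccccc32)cc1` in this assay gives > 100 ug/mL, again a limit. Compound 4 `O=C1/C(=C\c2cccc(Cl)c2)c2ccccc2N1c1c(Cl)cccc1Cl` differs from compound 3 by 3-chlorophenyl in place of 2-chlorophenyl on a double-bonded chain carbon bound to a double-bonded ring carbon. Steps at this position are an at least 100-fold higher number from compound 1 to compound 3 (2.00 log units; beyond the scatter) and a step that the two limits leave unreadable from compound 2 to compound 3; the step of an at least 100-fold higher number from compound 1 to compound 2 (2.00 log units; beyond the scatter) lies elsewhere. For the measured compounds named here, no measured step moves a chlorine around one ring, so the expected step of an at least 1.2-fold lower number from compound 3 to compound 4 (0.09 log units; that floor lies within the scatter) is small, and compound 4 is estimated at 80 ug/mL, between 20 ug/mL and 300 ug/mL.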

Compound 4, concentration for half-maximal effect: 7 ug/mL
Compound 4: the middle estimate sits 11-fold (1.06 log units) above what was measured; measured number outside the range, below it.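

In this assay, the place of the chlorine alone matters on this chain carbon: 3-chlorophenyl in place of 2-chlorophenyl gives an at least 14-fold lower number from compound 3 to compound 4 (1.15 log units; beyond the scatter). The 3-chlorophenyl group also differs from 4-methoxyphenyl, with an at least 14-fold lower number from compound 2 to compound 4 (1.15 log units; beyond the scatter), but does not match 4-(dimethylamino)phenyl, with an at least 7.0-fold higher number from compound 1 to compound 4 (0.84 log units; beyond the scatter). The first two sizes are only floors because compound 4 is compared with limits: the limit of > 100 ug/mL in this assay, at which 2 of the 4 values shown sit.

The compounds shown leave open how 4-chlorophenyl or 3-(dimethylamino)phenyl would read at this place, and whether an amine other than dimethylamino would stand closer to compound 1 or compound 4.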